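Benzyl in Place of 2-Fluorophenyl on an Aromatic Nitrogen

The source may hold more compounds than are shown below. What is called first, only, known or untested is meant among the compounds shown, and "the series" means these compounds.

Compound 2 `CC(C)n1ncc2c(C(=O)NCc3cn(-c4ccccc4F)nn3)cccc21` gives only a limit in a functional assay on MGC-803 cells (Homo sapiens) for inhibition, read by MTT assay, with a stated time of 72 h; a higher number here means a weaker inhibitor, a lower number a stronger inhibitor: compound 2 reaches > 40000 nM, a limit of the assay rather than a number. Compound 1 `CC(C)n1ncc2c(C(=O)NCc3cn(-c4cccc(F)c4)nn3)cccc21` likewise sits at a limit, and in this assay compound 1 shows > 40000 nM. The step that the two limits leave unreadable from compound 1 to compound 2 thus cannot be read, and the limit of > 40000 nM in this assay, at which 2 of the 2 values shown sit, is all the measured pair offers. Compound 3 `CC(C)n1ncc2c(C(=O)NCc3cn(Cc4ccccc4)nn3)cccc21` differs from compound 2 by benzyl in place of 2-fluorophenyl on an aromatic nitrogen. Among the measured compounds shown here, no measured step bears on this change, so no size or direction can be foreseen beyond the scatter, and the expected step that the limit leaves unreadable from compound 2 to compound 3 is set with wide uncertainty. Compound 3 is expected to give 60000 nM, within a range from 15000 nM to 200000 nM.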

Compound 3, half-maximal inhibitory concentration: 14300 nM
Compound 3: middle estimate off by 4.2-fold (0.62 log units), on the high side; measured number outside the range, below it.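

In this assay, a change on this aromatic nitrogen now gives a readable step: benzyl in place of 2-fluorophenyl gives an at least 2.7-fold lower number from compound 2 to compound 3 (0.44 log units; beyond the scatter), and benzyl in place of 3-fluorophenyl gives an at least 2.7-fold lower number from compound 1 to compound 3 (0.44 log units; beyond the scatter). On these data alone, both steps lie beyond the scatter, and each starts from a limit of the assay, so its full size remains unknown. The step between the two fluorophenyl compounds still cannot be read: the limit of > 40000 nM in this assay, at which 2 of the 3 values shown sit.

The compounds shown do not separate the loss of fluorine from the change to benzyl. As far as these compounds go, how a phenethyl chain or an amine on this nitrogen would behave also remains open.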